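Methoxy to ethoxy on the aromatic oxygen

A few compounds are considered here, and "the series" means these few. Any claim that something is new, unique, unknown or untested is made for them only; others in the source may bear on it.

Among the compounds with values here, in a functional assay on HCT-116 cells (Homo sapiens) for antiproliferative activity, with a stated time of 72 h (on this read-out lower numbers stand for stronger inhibition and higher numbers for weaker inhibition), compound 2 (`COc1ccccc1/C=C/c1nc2ccccc2c(=O)[nH]1`) gives 1460 nM and holds the lower of the two numbers so far, while compound 1 (`CC(=O)Oc1ccccc1/C=C/c1nc2ccccc2c(=O)[nH]1`) gives 17200 nM as the higher. Compound 3 (`CCOc1ccccc1/C=C/c1nc2ccccc2c(=O)[nH]1`) differs from compound 2 by methyl in place of hydrogen on a saturated chain carbon bound to an oxygen on an aromatic ring as methyl in place of hydrogen on a saturated chain carbon bound to an oxygen on an aromatic ring. Within the data shown here, the one measured step at that oxygen is the large 12-fold lower number from compound 1 to compound 2 (1.07 log units; beyond the scatter) for methyl in place of acetyl, a different change that gives no direct size for this one. A small step in this assay is expected, perhaps none beyond the scatter, with no firm direction. The estimated step is a 1.2-fold higher number from compound 2 to compound 3 (0.07 log units; within the scatter) for this change. Compound 3 is estimated at 1700 nM with 650 nM to 4500 nM as the expected range.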

Compound 3, half-maximal inhibitory concentration: 6430 nM
Beside the measured number, compound 3's estimate is 3.8-fold (0.58 log units) below it; the whole stated range lies below it.
By their numbers in this assay, from the lowest: compound 2; then compound 3; then compound 1.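

In this assay, the oxygen substituent proves sensitive to more than the acetyl swap: methyl in place of hydrogen on the saturated chain carbon gives a clear loss (a 4.4-fold higher number from compound 2 to compound 3 (0.64 log units; beyond the scatter)). Ethyl in place of acetyl gives a gain (a 2.7-fold lower number from compound 1 to compound 3 (0.43 log units; beyond the scatter)), so compound 3 falls between the other two compounds, and methoxy remains the best of the three groups at this oxygen. Nothing in hand explains the size of either step.

On these data alone, whether a propyl chain on this oxygen raises the number further remains open. So does whether a trifluoromethyl group in place of the methyl of compound 2 keeps the number near that of compound 2.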